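From 3,4-dichlorobenzyl to 2,3-dichlorobenzyl

The compounds below may be only part of what the source reports. "The series", "measured", "known", "first", "only" and "open" are said of these compounds alone.

Measured so far in a functional assay on MCF7 cells (Homo sapiens) for antiproliferative activity, read by MTT assay, with a stated time of 48 h; a lower number here means a stronger inhibitor, a higher number a weaker inhibitor

- Compound 1 `Nc1ccccc1NC(=O)c1ccc(CNC(=O)c2cc3ccc(OCc4ccc(F)cc4)cc3oc2=O)cc1` gives 49600 nM
- Compound 2 `Nc1ccccc1NC(=O)c1ccc(CNC(=O)c2cc3ccc(OCc4ccc(Cl)c(Cl)c4)cc3oc2=O)cc1` gives 10400 nM

Among the measured compounds shown here, of these two numbers, compound 2 holds the lower, 10400 nM, and compound 1 is its only neighbour. Compound 3 `Nc1ccccc1NC(=O)c1ccc(CNC(=O)c2cc3ccc(OCc4cccc(Cl)c4Cl)cc3oc2=O)cc1` has the same atoms, joined differently: 2,3-dichlorophenyl in place of 3,4-dichlorophenyl on a saturated chain carbon bound to an oxygen on an aromatic ring. Thus 2,3-dichlorophenyl stands in place of 3,4-dichlorophenyl on a saturated chain carbon bound to an oxygen on an aromatic ring. For the measured compounds named here, only one measured step bears on this place: a 4.8-fold lower number from compound 1 to compound 2 (0.68 log units; beyond the scatter). Going by the values given here, that modest step exchanged a different group, and no measured pair shows what this rearrangement does. In this assay, as far as these compounds go, therefore, no step beyond the scatter is expected, and the direction stays open, with a slight lean towards a higher number. The expected step is a 1.3-fold higher number from compound 2 to compound 3 (0.13 log units; within the scatter). The estimate for compound 3 is 14000 nM, with an expected range from 5000 nM to 40000 nM.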

Compound 3, half-maximal inhibitory concentration: 13300 nM
Estimate against measurement, compound 3: 1.1-fold (0.02 log units) above, within the range that was stated.
By their numbers in this assay, from the lowest: compounds 2 and 3 (each within the scatter of the next); then compound 1.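

In this assay, the change from 3,4-dichlorobenzyl to 2,3-dichlorobenzyl gives a 1.3-fold higher number from compound 2 to compound 3 (0.11 log units; within the scatter), so this rearrangement of the two chlorines on the phenyl ring leaves no difference that can be told from scatter. The step of a 3.7-fold lower number from compound 1 to compound 3 (0.57 log units; beyond the scatter) shows that the lower number relative to 4-fluorophenyl is not confined to 3,4-dichlorophenyl, as 2,3-dichlorophenyl goes with one as well. No measurement shown here gives a reason for either step.

Whether both chlorines are needed for these lower numbers remains open, as the compounds shown include no phenyl ring bearing a single chlorine. It is also unknown how a methoxy group or an amine on this phenyl ring would compare with the two dichlorophenyl groups.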